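The compounds below may be only part of what the source reports. "The series", "measured", "known", "first", "only" and "open" are said of these compounds alone.

Measured so far:
compound 1, `C=C1C[C@]23C[C@@]1(O)CC[C@H]2c1cc(Br)c(O)c(C)c1[C@@H]3Cn1cc(-c2ccccc2)nn1`: > 20000 nM
compound 2, `C=C1C[C@]23C[C@@]1(O)CC[C@H]2c1cc(Br)c(O)c(C)c1[C@@H]3Cn1cc(-c2ccc(C)cc2)nn1`: > 20000 nM

In a functional assay on SMMC-7721 cells (Homo sapiens) for cytotoxicity, read by MTT assay, with a stated time of 4 days (on this read-out higher numbers stand for weaker inhibition and lower numbers for stronger inhibition), compound 1 gives only a limit, > 20000 nM. Compound 2 likewise gives only a limit in this assay, > 20000 nM. Because both values sit at the limit of > 20000 nM in this assay, at which 2 of the 2 values shown sit, the step that the two limits leave unreadable from compound 1 to compound 2 cannot be sized, and compound 2 stands at the limit, not at a number. Compound 3, `C=C1C[C@]23C[C@@]1(O)CC[C@H]2c1cc(Br)c(O)c(C)c1[C@@H]3Cn1cc(-c2ccc(Cl)cc2)nn1`, differs from compound 2 by chloro in place of methyl on an aromatic carbon. Going by the values given here, no measured step speaks to a chloro group, so an estimated step that the limit leaves unreadable from compound 2 to compound 3 is expected, most likely none beyond the scatter. Compound 3 is therefore expected at 30000 nM, within 8000 nM to 100000 nM, probably again a limit.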

Compound 3, half-maximal inhibitory concentration: 19100 nM
Compound 3: the middle estimate sits 1.6-fold (0.20 log units) above what was measured; low and high end bracket the measured number.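

Chloro in the 4-chlorophenyl group, para to a large group, gives compound 3 a readable number where the earlier compounds gave only limits. The change shows an at least 1.0-fold lower number from compound 2 to compound 3 (0.01 log units; that floor lies within the scatter) and, starting from hydrogen, an at least 1.0-fold lower number from compound 1 to compound 3 (0.01 log units; that floor lies within the scatter). The full size of neither step can be read: the limit of > 20000 nM in this assay, at which 2 of the 3 values shown sit.

The compounds shown leave open how this position would respond to a quite different group, such as an amine or a carboxylic acid. They also leave open whether changes elsewhere on the shared core would move the number further.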